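The source may hold more compounds than are shown below. What is called first, only, known or untested is meant among the compounds shown, and "the series" means these compounds.

In an assay on isolated protein for inhibition of Fatty-acid amide hydrolase 1 (Rattus norvegicus) (on this read-out higher numbers stand for weaker inhibition and lower numbers for stronger inhibition), compound 1 `O=C(CCCCCCc1ccccc1)c1nc(Cl)co1` gives 4 nM, compound 2 `O=Cc1coc(C(=O)CCCCCCc2ccccc2)n1` gives 55 nM, and compound 3 `O=C(CCCCCCc1ccccc1)c1nc(-c2cccnc2)co1` gives 18 nM. Compound 3 therefore holds the second highest of the three numbers: its nearest neighbour is compound 2, reached by the downward step a 3.1-fold lower number from compound 2 to compound 3 (0.49 log units; beyond the scatter), while the step of a 4.5-fold higher number from compound 1 to compound 3 (0.65 log units; beyond the scatter) sets compound 1 further off. Compound 4 `CN(C)C(=O)c1coc(C(=O)CCCCCCc2ccccc2)n1` differs from compound 3 in one exchange on the shared core: dimethylcarbamoyl in place of pyridin-3-yl on an aromatic carbon. For the measured compounds named here, two measured steps bear on this change. Moving from chloro to a formyl, the step of a 14-fold higher number from compound 1 to compound 2 (1.14 log units; beyond the scatter) was large, and replacing that formyl by pyridin-3-yl recovered part of it in a 3.1-fold lower number from compound 2 to compound 3 (0.49 log units; beyond the scatter). Reversing the latter direction, from pyridin-3-yl to a carbonyl-bearing group, the account expects a modest rise in this assay, softened because a dimethylcarbamoyl is not the same carbonyl group as the formyl that gave a 14-fold higher number from compound 1 to compound 2 (1.14 log units; beyond the scatter); the expected step is a 2.2-fold higher number from compound 3 to compound 4 (0.35 log units; beyond the scatter). In this assay compound 4 is accordingly estimated at 40 nM, with a range from 12 nM to 130 nM.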

Compound 4, inhibition constant: 35 nM
Estimate against measurement, compound 4: 1.1-fold (0.06 log units) above; measured number inside the range.
By their numbers in this assay, from the lowest: compound 1; then compounds 3, 4 and 2 (each within the scatter of the next, the first and the last beyond it).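

At this place, on an aromatic carbon next to the ring nitrogen, exchanging the ring of pyridin-3-yl for the open dimethylcarbamoyl group gives a step within the scatter in this assay (a 1.9-fold higher number from compound 3 to compound 4 (0.29 log units; within the scatter)), so the presence of that ring is not needed to hold the number at this level. Dimethylamino in place of the formyl hydrogen also stays within the scatter (a 1.6-fold lower number from compound 2 to compound 4 (0.20 log units; within the scatter)), so compound 4 cannot be told apart from compound 2 or compound 3, although those two are separated by a step beyond the scatter. Chloro remains apart from this third group too (an 8.8-fold higher number from compound 1 to compound 4 (0.94 log units; beyond the scatter)), and compound 1 holds the lowest number of the four.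

Nothing shown gives a reason for these steps. From the compounds shown here alone, whether bromo, methyl or a carboxylic acid at this place would fall with compound 1 or with compounds 2, 3 and 4 remains open.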